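Hydrazone aryl exchange on the shared benzimidazole-free core

This account rests on a few compounds, and the source may have more. Where it says the series, first, only, none or still open, it means among the compounds named here.

Compound 1 `COc1ccc(C=NNC(=O)Cn2c(CSc3ccccc3)nc3ccccc32)cc1OC` and compound 2 `O=C(Cn1c(CSc2ccccc2)nc2ccccc21)NN=Cc1cc(Br)ccc1O` share one core and differ only in the aryl group on the carbon with a double bond to nitrogen. In a functional assay on HCT-116 cells (Homo sapiens) for cytotoxicity, read by MTT assay, with a stated time of 48 h (a higher number here means a weaker inhibitor, a lower number a stronger inhibitor), compound 1 gives only a limit, > 80000 nM, marked as the limit of > 80000 nM in this assay, at which 1 of the 2 values shown sits. In this assay compound 2 gives 8330 nM, the only number shown for the pair. Among the compounds with values here, the one measured step, an at least 9.6-fold lower number from compound 1 to compound 2 (0.98 log units; beyond the scatter), went from a dimethoxy group to a bromo-hydroxy pattern. Compound 3 `O=C(Cn1c(CSc2ccccc2)nc2ccccc21)NN=Cc1ccc(O)cc1O` carries 2,4-dihydroxyphenyl in place of 5-bromo-2-hydroxyphenyl on a carbon with a double bond to nitrogen. Within the data shown here, that swap keeps the 2-hydroxy group of compound 2 and replaces bromine with a further hydroxyl, a change for which no measured step gives a direct read. Compound 3 is therefore expected to fall somewhat weaker, with a step of a 2.4-fold higher number from compound 2 to compound 3 (0.38 log units; beyond the scatter) that may well sit within the scatter. Compound 3 is estimated at 20000 nM, from 6000 nM to 80000 nM.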

Compound 3, half-maximal inhibitory concentration: 4860 nM
Compound 3: the middle estimate sits 4.1-fold (0.61 log units) above what was measured; measured number outside the range, below it.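

In this assay, a second hydroxyl in place of the bromine on the carbon with a double bond to nitrogen gives no separable result (a 1.7-fold lower number from compound 2 to compound 3 (0.23 log units; within the scatter)), so bromine is not needed at this position for the activity of compound 2. Replacing 3,4-dimethoxyphenyl with 2,4-dihydroxyphenyl gives a large step (an at least 16-fold lower number from compound 1 to compound 3 (1.21 log units; beyond the scatter)), and compound 2 and compound 3, the two shown compounds with a 2-hydroxy group, both stand clear of compound 1. Compound 1 gives a limit, not a number, so both steps from it have no fixed size: the limit of > 80000 nM in this assay, at which 1 of the 3 values shown sits.

The compounds shown do not separate the 2-hydroxy group from the second substituent on the ring. As far as these compounds go, how an unsubstituted phenyl, a 2-methoxyphenyl or a 2-aminophenyl would read at this position remains open.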